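Swapping methyl for chloro on a sulfonamide-linked triazole series

The compounds below may be only part of what the source reports. "The series", "measured", "known", "first", "only" and "open" are said of these compounds alone.

Three compounds share one core, a uracil-type sulfonamide joined through an aromatic ring to a triazole that carries a second aromatic ring. Compound 1 `Cc1ccccc1-n1cc(-c2ccccc2NS(=O)(=O)c2c[nH]c(=O)[nH]c2=O)nn1` and compound 2 `O=c1[nH]cc(S(=O)(=O)Nc2ccccc2-c2cn(-c3ccccc3Cl)nn2)c(=O)[nH]1` attach the sulfonamide and the triazole to neighbouring positions of the central ring, while compound 3 `Cc1ccccc1-n1cc(-c2cccc(NS(=O)(=O)c3c[nH]c(=O)[nH]c3=O)c2)nn1` spaces them further apart. In a functional assay on A549 cells (Homo sapiens) for antiproliferative activity, read by MTT assay, with a stated time of 24 h (a lower number here means a stronger inhibitor, a higher number a weaker inhibitor), compound 1 gives 3210 nM, and compound 2 gives 2740 nM. In this assay compound 3 gives 5470 nM; its number is the highest of the three, yet the gaps to compound 1 and compound 2 both lie within the scatter, so no real difference is shown.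

Compound 4 `O=c1[nH]cc(S(=O)(=O)Nc2cccc(-c3cn(-c4ccccc4Cl)nn3)c2)c(=O)[nH]1` is the untested partner of compound 3, differing by chloro in place of methyl on an aromatic carbon. For the measured compounds named here, the only measured step of the same kind is a 1.2-fold lower number from compound 1 to compound 2 (0.07 log units; within the scatter), which did not move the number beyond the scatter. On that single precedent, the change from compound 3 to compound 4 is expected to leave this assay essentially unchanged, as a 1.2-fold lower number from compound 3 to compound 4 (0.08 log units; within the scatter).

For compound 4 the estimate in this assay is 4600 nM, with a likely range from 2200 nM to 9500 nM.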

Compound 4, half-maximal inhibitory concentration: 2730 nM
For compound 4 the middle estimate is 1.7-fold (0.23 log units) above the measured one; measured number inside the range.
By their numbers in this assay, from the lowest: compounds 4, 2, 1 and 3 (each within the scatter of the next).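

In this assay, changing 2-methylphenyl to 2-chlorophenyl on the core of compound 3 gives a 2.0-fold lower number from compound 3 to compound 4 (0.30 log units; within the scatter), so the same swap can now be read on a second core rather than on a single pair. The two readings agree, and the swap looks alike on both cores as far as these numbers can tell: the same change on two cores in this assay, a 1.2-fold lower number (0.07 log units; within the scatter) from compound 1 to compound 2 and a 2.0-fold lower number (0.30 log units; within the scatter) from compound 3 to compound 4, 1.7-fold (0.23 log units) apart, within the scatter of two such steps. At this position, on an aromatic carbon ortho to a large group, methyl and chloro therefore cannot be told apart in this assay on either core, and neither pair shows a real gain or loss from the change.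

Only these two groups are shown at this position, so it remains open whether a plain hydrogen, a methoxy group, an amine or a carboxylic acid there would move the number beyond the usual scatter. All four values also come from one assay on one cell type, so the compounds shown cannot say whether the swap would stay this quiet in other cells or at another exposure time.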